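A few compounds are considered here, and "the series" means these few. Any claim that something is new, unique, unknown or untested is made for them only; others in the source may bear on it.

Measured so far in the series:

compound 1 `Cn1ccc2c(Oc3ccc(NC(=O)c4cc5cccnc5n(-c5ccccc5)c4=O)cc3)ccnc21` — in a functional assay on NCI-H460 cells (Homo sapiens) for antiproliferative activity, read by MTT assay, with a stated time of 72 h (on this read-out higher numbers stand for weaker inhibition and lower numbers for stronger inhibition), compound 1 gives 560 nM
compound 2 `Cn1ccc2c(Oc3ccc(NC(=O)c4cc5cccnc5n(-c5ccc(Br)cc5)c4=O)cc3)ccnc21` — in this assay compound 2 gives "not determined" (no result reported)
compound 3 `COc1ccc(-n2c(=O)c(C(=O)Nc3ccc(Oc4ccnc5c4ccn5C)cc3)cc3cccnc32)cc1` — in this assay compound 3 gives 1920 nM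

Compound 3 therefore holds the higher of the two numbers available, set apart from compound 1 by a 3.4-fold higher number from compound 1 to compound 3 (0.54 log units; beyond the scatter). Among the compounds with values here, this is the single change on the ring attached to the aromatic nitrogen for which both ends have a number.

Compound 4 `Cn1ccc2c(Oc3ccc(NC(=O)c4cc5cccnc5n(-c5ccc(F)c(Cl)c5)c4=O)cc3)ccnc21` differs from compound 3 by 3-chloro-4-fluorophenyl in place of 4-methoxyphenyl on an aromatic nitrogen. Within the data shown here, no measured step covers a halogen on that ring; compound 2 carries a bromine there, but no number exists for it. Among the measured compounds shown here, the only step that bears on the position is a 3.4-fold higher number from compound 1 to compound 3 (0.54 log units; beyond the scatter), a modest rise on going from hydrogen to methoxy. Compound 4 takes the methoxy away again and puts chlorine and fluorine in its place, which the data do not cover in either direction. The working expectation is that compound 4 returns toward the number of compound 1 rather than moving further up, with wide uncertainty.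

In this assay compound 4 is expected at about 900 nM, within a range of 350 nM to 2500 nM. That estimate means a step of a 2.1-fold lower number from compound 3 to compound 4 (0.33 log units; beyond the scatter), only just beyond the scatter.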

Compound 4, half-maximal inhibitory concentration: 1210 nM
For compound 4 the middle estimate is 1.3-fold (0.13 log units) below the measured one, within the range that was stated.
By their numbers in this assay, from the lowest: compound 1; then compounds 4 and 3 (each within the scatter of the next).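

In this assay, a ring carrying halogens now has a number at this position, and a 2.2-fold higher number from compound 1 to compound 4 (0.33 log units; beyond the scatter) places 3-chloro-4-fluorophenyl apart from the unsubstituted phenyl. Both substituted rings with a number, in compound 3 and compound 4, thus stand on the higher side of compound 1, and no numbered compound goes against this, although two compounds are a thin base for a pattern. The exchange of 4-methoxyphenyl for 3-chloro-4-fluorophenyl, read as a 1.6-fold lower number from compound 3 to compound 4 (0.20 log units; within the scatter), does not separate the two groups, so on these numbers an oxygen-linked methyl and a pair of halogens cannot be told apart here, and no measurement at hand speaks to what lies behind these numbers.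

Compound 2 has no number, which leaves a lone bromine on this ring unplaced, and with it the question of whether one halogen alone stands with compound 1 or with compound 4. Also open, as far as these compounds go, is how a ring bearing an amine or a carboxylic acid would stand, and whether a smaller ring or a short alkyl chain in place of the phenyl would fall below compound 1.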